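Replacing 3-Bromophenyl with 2,4-Dichlorophenyl

The source may hold more compounds than are shown below. What is called first, only, known or untested is meant among the compounds shown, and "the series" means these compounds.

In a functional assay on MCF7 cells (Homo sapiens) for cytotoxicity, read by MTT assay, with a stated time of 72 h (on this read-out lower numbers stand for stronger inhibition and higher numbers for weaker inhibition), compound 1 (`COc1cc(/C=C2\CCC/C(=C\c3cccc(OC)c3OC)C2=O)cc(OC)c1`) gives 1700 nM, while compound 2 (`COc1ccc(/C=C2\CCC/C(=C\c3cccc(Br)c3)C2=O)cc1OC`) gives 5300 nM, the higher of the two numbers and so the weaker result, a gap beyond the scatter. Compound 3 (`COc1ccc(/C=C2\CCC/C(=C\c3ccc(Cl)cc3Cl)C2=O)cc1OC`) carries 2,4-dichlorophenyl in place of 3-bromophenyl on a double-bonded chain carbon bound to a double-bonded ring carbon. Going by the values given here, no measured pair shows a change of this kind, so the expectation is loose. The expected step of a 1.8-fold lower number from compound 2 to compound 3 (0.25 log units; within the scatter) is a slight drop that stays within the scatter. In this assay, compound 3 is estimated at 3000 nM, with a range from 1000 nM to 9000 nM.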

Compound 3, half-maximal inhibitory concentration: 16200 nM
Compound 3: middle estimate off by 5.4-fold (0.73 log units), on the low side, outside the stated range (above it).
By their numbers in this assay, from the lowest: compound 1; then compound 2; then compound 3.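

In this assay, putting 2,4-dichlorophenyl in place of 3-bromophenyl on a double-bonded chain carbon bound to a double-bonded ring carbon gives a 3.1-fold higher number from compound 2 to compound 3 (0.49 log units; beyond the scatter), a modest weakening beyond the scatter. This is the first single-place change shown, and it makes clear that the result depends on which halogen-bearing phenyl sits here. No measurement at hand explains the loss. The compounds shown cannot separate swapping bromine for chlorine from adding a second halogen. On these data alone, how an amine or a carboxylic acid on this phenyl would fare also stays open.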